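The source may hold more compounds than are shown below. What is called first, only, known or untested is meant among the compounds shown, and "the series" means these compounds.

Compound 2 `CN(c1ccccc1CCCn1nnnc1[C@@H](COCc1ccccc1)NC(=O)C(C)(C)N)S(C)(=O)=O` gives the highest number of the three measured in an assay on isolated protein for displacement of a labelled ligand from growth hormone secretagogue receptor type 1 (Homo sapiens), with a stated time of 1 h (a higher number here means a weaker inhibitor, a lower number a stronger inhibitor), at 1720 nM; compound 1 `CC(C)(N)C(=O)N[C@H](COCc1ccccc1)c1nnnn1CCCc1ccccc1` gives 200 nM and compound 3 `COC(=O)C(c1ccccc1)n1nnnc1[C@@H](COCc1ccccc1)NC(=O)C(C)(C)N` gives 470 nM. Compound 4 `CC(C)(N)C(=O)N[C@H](COCc1ccccc1)c1nnnn1CCCCCNS(C)(=O)=O` differs from compound 2 by 2-(methanesulfonamido)ethyl in place of 2-(methyl(methylsulfonyl)amino)phenyl on a saturated chain carbon, three bonds along the chain from an aromatic nitrogen. For the measured compounds named here, two measured steps bear on this change: an 8.6-fold higher number from compound 1 to compound 2 (0.93 log units; beyond the scatter), and a 2.4-fold higher number from compound 1 to compound 3 (0.37 log units; beyond the scatter). Since the group that enters in compound 2 raised the number and the chain on the aromatic nitrogen in compound 3 moved it only modestly, a modest step back toward a lower number is expected in this assay, although the aromatic ring that leaves is not accounted for by any measured pair. Compound 4 is therefore estimated at 1000 nM, with a range of 300 nM to 3500 nM, an expected step of a 1.7-fold lower number from compound 2 to compound 4 (0.24 log units; within the scatter).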

Compound 4, inhibition constant: > 5000 nM
Compound 4 was reported as a limit; the forecaster's own chance of this, stated with the estimate: 10%; middle value at least 5.0-fold (0.69 log units) from the limit.
By their numbers in this assay, from the lowest: compound 1; then compound 3; then compound 2. At a limit, above all of these: compound 4.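

Compound 4 is reported in this assay only as a limit: the limit of > 5000 nM in this assay, at which 1 of the 4 values shown sits. Replacing 2-(methyl(methylsulfonyl)amino)phenyl with 2-(methanesulfonamido)ethyl gives an at least 2.9-fold higher number from compound 2 to compound 4 (0.46 log units; beyond the scatter), so the aromatic ring on this chain matters more than the step from compound 1 to compound 2 suggested. Compound 4 is the only compound shown without a six-membered aromatic ring on this side of the molecule, and the other steps are an at least 25-fold higher number from compound 1 to compound 4 (1.39 log units; beyond the scatter) and an at least 10-fold higher number from compound 3 to compound 4 (1.02 log units; beyond the scatter).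

The compounds shown leave open whether the loss follows from the missing ring or from the sulfonamide hydrogen that enters. An unsubstituted pentyl chain, or an amine or carboxylic acid at the end of the chain, could separate these two changes.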